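This account rests on a few compounds, and the source may have more. Where it says the series, first, only, none or still open, it means among the compounds named here.

Compound 3 (`Cc1cn2c(-c3cn[nH]c3)cnc2c(Nc2cc(Cc3cccnc3)ns2)n1`) carries a (pyridin-3-yl)methyl group on the shared core, and in an ADME assay on the whole organism for pharmacokinetics, with Rattus norvegicus as the target, with a stated time of 6 h, at a dose of 10 mg/kg by the oral route (on this read-out lower numbers stand for lower exposure and higher numbers for higher exposure at the dose given), compound 3 gives "not determined" (no result reported), so there is no single number to place it against. Its closest measured neighbours are compound 1 (`Cc1cn2c(-c3cn[nH]c3)cnc2c(Nc2cc(Cc3nccs3)ns2)n1`), which in this assay gives 1540 ng.h/mL, and compound 2 (`Cc1cn2c(-c3cn[nH]c3)cnc2c(Nc2cc(Cc3ccccn3)ns2)n1`), which in this assay gives 6880 ng.h/mL. Among the measured compounds shown here, the one step between them, a 4.5-fold higher number from compound 1 to compound 2 (0.65 log units; beyond the scatter), shows that the group on the saturated chain carbon bound to an aromatic carbon can move exposure by a modest amount. Compound 4 (`Cc1cn2c(-c3cn[nH]c3)cnc2c(Nc2cc(Cc3ccc(F)cn3)ns2)n1`) differs from compound 3 by 5-fluoropyridin-2-yl in place of pyridin-3-yl on a saturated chain carbon bound to an aromatic carbon. For the measured compounds named here, no measured step covers this exact change; compound 2 is the nearest measured reference for a pyridin-2-yl at this position, and from its value exposure of compound 4 in this assay is expected to lie in the same region, with no step beyond the scatter predicted from compound 3. Compound 4 is therefore estimated to give 5000 ng.h/mL in this assay, within a range of 1500 ng.h/mL to 15000 ng.h/mL.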

Compound 4, area under the concentration-time curve: 2240 ng.h/mL
Compound 4: the middle estimate sits 2.2-fold (0.35 log units) above what was measured; the measured number falls inside the stated range.
By their numbers in this assay, from the lowest: compounds 1 and 4 (each within the scatter of the next); then compound 2.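

In this assay the position responds to a change as small as fluoro in place of hydrogen on an aromatic carbon, not only to an exchange of whole rings (a 3.1-fold lower number from compound 2 to compound 4 (0.49 log units; beyond the scatter)). With that fluoro present, the 5-fluoropyridin-2-yl group no longer stands clear of the 1,3-thiazol-2-yl group (a 1.5-fold higher number from compound 1 to compound 4 (0.16 log units; within the scatter)), whereas the unsubstituted pyridin-2-yl group of compound 2 does. Nothing at hand bears on what lies behind either step.

Steps that involve compound 3 cannot be read, so the place of pyridin-3-yl relative to the other groups at this position remains unknown. Going by these compounds, it also stays open whether a chloro or a methoxy group in place of the fluoro would lower the number as the fluoro does, or leave it near that of compound 2.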